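Furan-2-yl in place of cyclohexyl on the carbonyl carbon

A few compounds are considered here, and "the series" means these few. Any claim that something is new, unique, unknown or untested is made for them only; others in the source may bear on it.

Compound 1 `COc1ccc(C(=O)NC(=S)N2CCc3c(OCCCCCOc4ccc(Cl)cc4)cccc32)cc1` gives 34400 nM in an ADME assay on Huh-7 cells (Homo sapiens) for cytotoxicity; a lower number here means that less compound is tolerated, a higher number that more compound is tolerated. Compound 2 `O=C(NC(=S)N1CCc2c(OCCCCCOc3ccc(Cl)cc3)cccc21)C1CCCCC1` is reported in this assay only as a limit, > 50000 nM, as recorded by the limit of > 50000 nM in this assay, at which 1 of the 2 values shown sits. The step of an at least 1.4-fold higher number from compound 1 to compound 2 (0.16 log units; that floor lies within the scatter) is therefore bounded only from below. Compound 3 `O=C(NC(=S)N1CCc2c(OCCCCCOc3ccc(Cl)cc3)cccc21)c1ccco1` differs from compound 2 by furan-2-yl in place of cyclohexyl on a carbonyl carbon. Within the data shown here, only that one measured step bears on this change, and its floor lies within the scatter, so for compound 3 the step of an at least 1.2-fold lower number from compound 2 to compound 3 (0.09 log units; that floor lies within the scatter) is expected to stay within the scatter or give back part of the rise seen with compound 1. Compound 3 is estimated at 40000 nM, within 18000 nM to 90000 nM.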

Compound 3, half-maximal cytotoxic concentration: 4620 nM
For compound 3 the middle estimate is 8.7-fold (0.94 log units) above the measured one, and the stated range ends above it.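

In this assay, the group on the carbonyl carbon proves able to shift the number well beyond the scatter, which the floor of the earlier step could not show: an at least 10-fold lower number from compound 2 to compound 3 (1.03 log units; beyond the scatter) for furan-2-yl against cyclohexyl, and a 7.4-fold lower number from compound 1 to compound 3 (0.87 log units; beyond the scatter) against 4-methoxyphenyl. The lowest tolerated concentration thus goes with the furan-2-yl group, not with either larger ring. Compound 2 stands at a limit, so the first step is only a floor: the limit of > 50000 nM in this assay, at which 1 of the 3 values shown sits.

Going by these compounds, whether thiophen-2-yl or plain phenyl on this carbonyl carbon would behave like furan-2-yl remains open. So does whether the lower number goes with the ring oxygen or the ring size.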